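Moving a Hydroxyl Group on a Shared Pyridine Core

The compounds below may be only part of what the source reports. "The series", "measured", "known", "first", "only" and "open" are said of these compounds alone.

Within the data shown here, compound 2 `Oc1cccc(-c2cc(-c3ccco3)cc(-c3ccccc3O)n2)c1` has the higher of the two numbers measured so far in a functional assay on DU-145 cells (Homo sapiens) for cytotoxicity, read by CCK-8 assay (a lower number here means a stronger inhibitor, a higher number a weaker inhibitor), giving 1790 nM; compound 1 `Oc1cccc(-c2cc(-c3cccs3)cc(-c3cccc(O)c3)n2)c1` sits within the scatter of it at 1630 nM. Compound 3 `Oc1cccc(-c2cc(-c3ccco3)cc(-c3cccc(O)c3)n2)c1` differs from compound 2 only in the position of one hydroxyl: 3-hydroxyphenyl in place of 2-hydroxyphenyl on an aromatic carbon. Among the measured compounds shown here, no measured pair shows the effect of this change directly, so any shift in this assay is expected to stay within the scatter, with no clear direction. Compound 3 is therefore estimated at 1500 nM, within a range of 700 nM to 3500 nM, a step of a 1.2-fold lower number from compound 2 to compound 3 (0.08 log units; within the scatter).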

Compound 3, half-maximal inhibitory concentration: 2150 nM
Estimate against measurement, compound 3: 1.4-fold (0.16 log units) below; measured number inside the range.
By their numbers in this assay, from the lowest: compounds 1, 2 and 3 (each within the scatter of the next).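

In this assay, moving the hydroxyl, with 3-hydroxyphenyl in place of 2-hydroxyphenyl next to the ring nitrogen, gives a 1.2-fold higher number from compound 2 to compound 3 (0.08 log units; within the scatter), so this position tolerates the swap without a readable shift. Compound 3 also supplies a second direct comparison, furan-2-yl in place of thiophen-2-yl, which gives a 1.3-fold higher number from compound 1 to compound 3 (0.12 log units; within the scatter) and likewise stays within the scatter. No supporting data bear on these results. Still open, on these data alone, is whether an amine or a carboxylic acid in place of the hydroxyl would produce a step beyond the scatter.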